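Fluoro in place of nitro on the shared core

The source may report more compounds than this note shows. Statements on the series, on what has been measured and on what is new or still open speak of the compounds shown alone.

Compound 1 `CCCCOc1ccccc1/C=C/C(=O)c1ccc(OC)c(OC)c1OC` at 52000 nM
Compound 2 `COc1ccc(C(=O)/C=C/c2ccccc2[N+](=O)[O-])c(OC)c1OC` at 7000 nM
Compound 3 `COc1ccc(C(=O)/C=C/c2ccccc2F)c(OC)c1OC` not yet measured

Of the two measured compounds in a functional assay (Homo sapiens) for inhibition (a higher number here means a weaker inhibitor, a lower number a stronger inhibitor), compound 2 has the lower number at 7000 nM and is the stronger inhibitor. Compound 3 carries fluoro in place of nitro on an aromatic carbon, ortho to a large group (fluoro in place of nitro on an aromatic carbon). For the measured compounds named here, one measured step bears on this, a modest one that changes the group on that same carbon (a 7.4-fold lower number from compound 1 to compound 2 (0.87 log units; beyond the scatter)). It gives no measure for fluoro, so a modest rise of similar or smaller size is expected. The expected step is modest (a 2.3-fold higher number from compound 2 to compound 3 (0.36 log units; beyond the scatter)). Compound 3 is expected at 16000 nM (estimated range 4000 nM to 60000 nM).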

Compound 3, half-maximal inhibitory concentration: 11000 nM
Compound 3: the middle estimate sits 1.5-fold (0.16 log units) above what was measured; measured number inside the range.
By their numbers in this assay, from the lowest: compounds 2 and 3 (each within the scatter of the next); then compound 1.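

In this assay, fluoro in place of nitro on this aromatic carbon gives a 1.6-fold higher number from compound 2 to compound 3 (0.20 log units; within the scatter) and so does not separate the two groups, although fluoro has one heavy atom and nitro three. Fluoro in place of butoxy gives a 4.7-fold lower number from compound 1 to compound 3 (0.67 log units; beyond the scatter) and shows that the lower number seen with nitro is not unique to nitro. No measurement given here accounts for these results. Going by these compounds, whether an amine or a carboxylic acid on this carbon would fit with fluoro and nitro or with butoxy remains open. So does whether fluoro would give a similar number on another carbon of this ring.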